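The source may hold more compounds than are shown below. What is called first, only, known or untested is meant among the compounds shown, and "the series" means these compounds.

Going by the values given here, compound 1, `Cc1ccc(Nc2cc(NC(=O)Nc3c(Cl)cccc3Cl)ncn2)cc1F`, and compound 2, `COc1cc(NC(=O)Nc2cc(Nc3ccc(C)c(C)c3)ncn2)cc(OC)c1`, share a core carrying a urea on one side and an arylamino group on the other, and differ in both side groups at once, so no single step between them is counted. In a functional assay on HCC827 cells (Homo sapiens) for inhibition, read by MTT assay, with a stated time of 48 h, tested at 10 uM (on this read-out lower numbers stand for less inhibition and higher numbers for more inhibition at the one concentration tested (going by the name of the read-out)), compound 1 gives 85.3%. In this assay, among the compounds with values here, compound 2 gives 45.7%, the lower of the two numbers known, standing beyond the scatter under compound 1. Compound 3, `COc1cc(NC(=O)Nc2cc(Nc3ccc(C)c(F)c3)ncn2)cc(OC)c1`, keeps the dimethoxyphenyl urea of compound 2 and changes only the arylamino group: fluoro in place of methyl on an aromatic carbon, the change sitting on an aromatic carbon of a six-membered aromatic ring of carbon only, ortho to a methyl group and meta to a large group. Within the data shown here, the only comparison at hand, that of compound 1 to compound 2, confounds this change with the urea side, so it gives no clean guide; a step of modest size upward in this assay is expected for compound 3, and it may well lie within the scatter. The expected step is a number 7.3 percentage points higher from compound 2 to compound 3 (within the scatter). Compound 3 is thus estimated at 53%, in the range 30% to 76%.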

Compound 3, a percentage reported as inhibition, at one concentration (the size of the read-out at that concentration, not a potency): 72%
For compound 3 the middle estimate is 19 percentage points below the measured one, within the range that was stated.
By their numbers in this assay, from the lowest: compound 2; then compound 3; then compound 1.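

With the dimethoxyphenyl urea held fixed, the arylamino side can now be read alone: in this assay, fluoro in place of methyl on an aromatic carbon, ortho to a methyl group and meta to a large group, gives a number 26.3 percentage points higher from compound 2 to compound 3 (beyond the scatter). The earlier pair, compound 1 and compound 2, differed in both side groups and could not show this, whereas the change from 3,4-dimethylphenyl to 3-fluoro-4-methylphenyl now shows that this one position can by itself move the number beyond the scatter, with the urea side unchanged. Nothing at hand bears on why the number rises with this exchange of one heavy atom for another.

The compounds shown leave open whether this rise belongs to fluoro in particular or would also come with chloro, methoxy or an amine on the same carbon. They also leave open whether the same exchange would give a step of similar size with the urea side of compound 1, and how it would read as a potency rather than at the one concentration tested.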